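Working notes: 4-nitrophenyl to 3-nitrophenyl

A few compounds are considered here, and "the series" means these few. Any claim that something is new, unique, unknown or untested is made for them only; others in the source may bear on it.

Two compounds of the series have results in an ADME assay on MT4 cells (Homo sapiens) for cytotoxicity, read by MTT assay, with a stated time of 3 days (a higher number here means that more compound is tolerated, a lower number that less compound is tolerated), and neither gives a single number. Compound 1 (`CC(C)(C)N(CCC(=O)c1ccccc1)C(=O)COC(=O)c1ccc([N+](=O)[O-])o1`) is reported as "not active" (no number reported), without a figure. Compound 2 (`CC(C)(C)N(Cc1ccc([N+](=O)[O-])cc1)C(=O)COC(=O)c1ccc([N+](=O)[O-])o1`) gives > 100000 nM, which is a limit of the assay and not a number. For the measured compounds named here, compound 2 therefore has no exact position on the scale, and no measured step is available to calibrate the next one.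

Compound 3 (`CC(C)(C)N(Cc1cccc([N+](=O)[O-])c1)C(=O)COC(=O)c1ccc([N+](=O)[O-])o1`) has the same atoms as compound 2, joined differently, with 3-nitrophenyl in place of 4-nitrophenyl on a saturated chain carbon bound to an amide-type nitrogen. The step of a number no higher from compound 2 to compound 3 (the limit leaves the size open) is expected to stay within the usual scatter, with no direction favoured. This expectation rests on compound 2, whose > 100000 nM is a limit, and on the unchanged atom content of the swapped group. A result for compound 3 reported only as a limit would therefore be unsurprising. Compound 3 is estimated at 100000 nM, with an expected range from 40000 nM to 200000 nM.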

Compound 3, half-maximal cytotoxic concentration: > 100000 nM
Compound 3: only a limit was reported (the forecaster's own chance of this, stated with the estimate: 75%); the middle value lies on the limit itself.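

For the compounds shown here, the results for compound 2 and compound 3 are both limits of the assay and not numbers, so no step between the two can be read: the limit of > 100000 nM in this assay, at which 2 of the 3 values shown sit.

Left open is how much of either compound is tolerated in this assay and whether 4-nitrophenyl and 3-nitrophenyl differ there at all.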